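Replacing the 4-methoxyphenyl group of compound 1

The source may report more compounds than this note shows. Statements on the series, on what has been measured and on what is new or still open speak of the compounds shown alone.

Compound 1 `COc1ccc(/C=C(/Sc2ccc(C)cc2)C(=O)c2ccc(Br)cc2)cc1` gives 50000 nM
Compound 2 `COc1ccc(/C=C(/SCc2ccc(Cl)cc2)C(=O)c2ccc(Br)cc2)cc1` gives 10000 nM
Compound 3 `COc1ccc(/C=C(/Sc2ccc(C)cc2)C(=O)c2ccc(Cl)cc2)cc1` gives 1000 nM

All three values come from a functional assay on DU-145 cells (Homo sapiens) for inhibition, read by trypan blue exclusion, with a stated time of 96 h (a higher number here means a weaker inhibitor of growth, a lower number a stronger inhibitor of growth), and compound 1 has the highest number, which makes it the weakest of the three, since its steps to both others lie beyond the scatter.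

Compound 4 `Cc1ccc(S/C(=C/c2ccc(F)cc2F)C(=O)c2ccc(Br)cc2)cc1` has not yet been measured. It differs from compound 1 by 2,4-difluorophenyl in place of 4-methoxyphenyl on a double-bonded chain carbon bound to a double-bonded chain carbon as 2,4-difluorophenyl in place of 4-methoxyphenyl on a double-bonded chain carbon bound to a double-bonded chain carbon, and the rest of the structure stays the same.

Going by the values given here, no measured step touches that place. Two steps do start from compound 1, namely a 5.0-fold lower number from compound 1 to compound 2 (0.70 log units; beyond the scatter) for 4-chlorobenzyl in place of 4-methylphenyl on a sulfur, and a 50-fold lower number from compound 1 to compound 3 (1.70 log units; beyond the scatter) for chloro in place of bromo on an aromatic carbon. Both changes lie elsewhere, so neither gives the size of this one directly. Among the compounds with values here, they show only that a single change to compound 1 has lowered the number by a modest and by a large amount. A modest step downward is therefore expected, with wide uncertainty, and a step within the scatter remains possible. The expected change is a 5.0-fold lower number from compound 1 to compound 4 (0.70 log units; beyond the scatter) in this assay as a rough estimate. In this assay the estimate for compound 4 is 10000 nM with a range from 1500 nM to 60000 nM as the expected span.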

Compound 4, concentration for 50% growth inhibition: > 100000 nM
Compound 4 was reported as a limit; the forecaster's own chance of this, stated with the estimate: 10%; middle value at least 10-fold (1.00 log units) from the limit.
By their numbers in this assay, from the lowest: compound 3; then compound 2; then compound 1. At a limit, above all of these: compound 4.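

In this assay compound 4 gives > 100000 nM, which is a limit of the assay and not a number. At this position, on a double-bonded chain carbon bound to a double-bonded chain carbon, putting 2,4-difluorophenyl in place of 4-methoxyphenyl gives an at least 2.0-fold higher number from compound 1 to compound 4 (0.30 log units; that floor lies within the scatter), whereas the two earlier single changes, made elsewhere on compound 1, gave a 5.0-fold lower number from compound 1 to compound 2 (0.70 log units; beyond the scatter) and a 50-fold lower number from compound 1 to compound 3 (1.70 log units; beyond the scatter). This is thus the first place on compound 1 where a single change does not lower the number, although the printed floor alone does not put the rise beyond the scatter, and the true size of the step stays unknown: the limit of > 100000 nM in this assay, at which 1 of the 4 values shown sits.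

The compounds shown leave open whether the result follows from losing the 4-methoxyphenyl group or from bringing in the 2,4-difluorophenyl group, since this position is represented by only these two groups. They also leave open how an unsubstituted phenyl, or a phenyl carrying an amine or a carboxylic acid, would read at the same place, and whether the chloro in place of bromo step would hold on the 2,4-difluorophenyl compound.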